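From 2-cyanoethyl to 2-cyanoethenyl on compound 3

This account rests on a few compounds, and the source may have more. Where it says the series, first, only, none or still open, it means among the compounds named here.

In a physicochemical assay for lipophilicity, at pH 7.4 (on this read-out lower numbers stand for lower lipophilicity and higher numbers for higher lipophilicity), compound 3 `COC(=O)c1cc(N)c(Nc2ccc(C#N)cc2)cc1Oc1c(C)cc(CCC#N)cc1C` reads 4.15 and stands above compound 1 `Cc1cc(/C=C/C#N)cc(C)c1Oc1cc(Nc2ccc(C#N)cc2)c(N)cc1C(N)=O` at 3.53 among the numbers available. Compound 2 `Cc1cc(/C=C/C#N)cc(C)c1Oc1cc(Nc2ccc(C#N)cc2)c(N)cc1[N+](=O)[O-]` returns > 5 as a limit of the assay. Compound 4 `COC(=O)c1cc(N)c(Nc2ccc(C#N)cc2)cc1Oc1c(C)cc(/C=C/C#N)cc1C` carries 2-cyanoethenyl in place of 2-cyanoethyl on an aromatic carbon. For the measured compounds named here, the only measured step (a number at least 1.47 log units higher from compound 1 to compound 2 (beyond the scatter)) is large, but it swaps carbamoyl for nitro and so bears on this change only weakly. Going by the values given here, no measured step covers the side chain itself. A small rise in this assay is expected, close to the scatter (a number 0.25 log units higher from compound 3 to compound 4 (within the scatter)). Compound 4 is estimated at 4.4 (expected range 4 to 4.9).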

Compound 4, partition coefficient: 4.15
The estimate for compound 4 lay 0.25 log units above the measured number; the range from low to high includes it.
By their numbers in this assay, from the lowest: compound 1; then compounds 3 and 4 (each within the scatter of the next). At a limit, above all of these: compound 2.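

In this assay, 2-cyanoethenyl in place of 2-cyanoethyl on this aromatic carbon gives no change at the digits printed from compound 3 to compound 4 (within the scatter), so at this position, meta to two methyl groups, the read-out does not separate the two side chains. Changes at the other site do separate compounds: methoxy in place of amino on the carbonyl carbon gives a number 0.62 log units higher from compound 1 to compound 4 (beyond the scatter), and methoxycarbonyl in place of nitro gives a number at least 0.85 log units lower from compound 2 to compound 4 (beyond the scatter). The figure for compound 2 is a limit, not a number: the limit of > 5 in this assay, at which 1 of the 4 values shown sits.

On these data alone, whether the side-chain result holds with carbamoyl or nitro on the core stays open. Also open, as far as these compounds go, is how a carboxylic acid, an amine or a longer chain would read on this aromatic carbon.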